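This account rests on a few compounds, and the source may have more. Where it says the series, first, only, none or still open, it means among the compounds named here.

Compound 2 `O=C1[C@@H](n2cc(-c3ccccc3)nn2)[C@@H](/C=C/c2ccccc2)N1C1CCCCC1` gives 99.7% in a functional assay on KB cells (Homo sapiens) for inhibition, tested at 100 uM (on this read-out higher numbers stand for more inhibition of growth at the one concentration tested and lower numbers for less inhibition of growth), the higher of the two numbers measured; compound 1 `Cc1ccc(N2C(=O)[C@@H](n3cc(-c4ccccc4)nn3)[C@H]2/C=C/c2ccccc2)cc1` gives 80.8%. Compound 3 `O=C1[C@@H](n2cc(-c3ccccc3)nn2)[C@@H](/C=C/c2ccccc2)N1c1ccc(Cl)cc1` differs from compound 2 by 4-chlorophenyl in place of cyclohexyl on an amide-type nitrogen in a ring. Among the compounds with values here, the only step that bears on this is a number 18.9 percentage points higher from compound 1 to compound 2 (beyond the scatter), where an aryl group on that nitrogen was replaced by cyclohexyl. Since the change now runs back toward an aryl group, compound 3 is expected to fall by a number 14.7 percentage points lower from compound 2 to compound 3 (beyond the scatter). Compound 3 is therefore estimated at 85%, within a range from 65% to 99%.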

Compound 3, percent growth inhibition at one concentration: 79.3%
Compound 3: the middle estimate sits 5.7 percentage points above what was measured; the measured number falls inside the stated range.
By their numbers in this assay, from the lowest: compounds 3 and 1 (each within the scatter of the next); then compound 2.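

In this assay, 4-chlorophenyl in place of cyclohexyl gives a number 20.4 percentage points lower from compound 2 to compound 3 (beyond the scatter), so both aryl groups on this amide-type nitrogen now stand below cyclohexyl. Between the two aryl groups the result is a number 1.5 percentage points lower from compound 1 to compound 3 (within the scatter), and chloro and methyl on the aromatic carbon cannot be told apart here. Nothing available explains these results.

On these data alone, whether the higher number belongs to cyclohexyl alone or extends to other non-aromatic groups stays open; a cyclopentyl group or a butyl chain would test this. As far as these compounds go, how a methoxy group on the phenyl ring would read also remains open.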